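The source may report more compounds than this note shows. Statements on the series, on what has been measured and on what is new or still open speak of the compounds shown alone.

Measured compounds:
compound 1 `O=C(O)CCC1=CC[C@@H]2[C@@H](/C=C/[C@@H](O)COc3ccccc3)[C@H](O)C[C@@H]2OC1`; in an ADME assay on CHO cells for agonist activity at prostacyclin receptor (Homo sapiens), read by HTRF and cAMP accumulation (on this read-out lower numbers stand for an effect already at smaller amounts and higher numbers for an effect only at larger amounts of compound), compound 1 gives > 10000 nM, a limit of the assay.
compound 2 `O=C(O)CCCC1=CC[C@@H]2[C@@H](/C=C/[C@@H](O)COc3ccccc3)[C@H](O)C[C@@H]2OC1`; in this assay compound 2 gives > 10000 nM, also a limit.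
compound 3 `O=C(O)CCC[C@@H]1CC[C@@H]2[C@@H](/C=C/[C@@H](O)COc3ccccc3)[C@H](O)C[C@@H]2OC1`; in this assay compound 3 gives > 10000 nM, again a limit.

The change from compound 1 to compound 2 is carboxymethyl in place of carboxy on a saturated chain carbon, two bonds along the chain from a double-bonded ring carbon, and its step that the two limits leave unreadable from compound 1 to compound 2; both ends sit at the limit of > 10000 nM in this assay, at which 3 of the 3 values shown sit. How the core of compound 3 differs from the core of compound 1 is not broken down here. Compound 4 `O=C(O)CCCC[C@@H]1CC[C@@H]2[C@@H](/C=C/[C@@H](O)COc3ccccc3)[C@H](O)C[C@@H]2OC1` is not yet measured in this assay and arises from compound 3 by carboxymethyl in place of carboxy on a saturated chain carbon, three bonds along the chain from a saturated ring carbon, the same kind of change, though placed on a saturated chain carbon, three bonds along the chain from a saturated ring carbon rather than two bonds along the chain from a double-bonded ring carbon. Because every measured value sits at the limit of > 10000 nM in this assay, at which 3 of the 3 values shown sit, the step that the limit leaves unreadable from compound 3 to compound 4 is expected to stay unreadable. Compound 4 is therefore expected near 12000 nM, within 4000 nM to 40000 nM, most probably again as a limit.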

Compound 4, half-maximal effective concentration: > 10000 nM
Compound 4 was reported as a limit; the forecaster's own chance of this, stated with the estimate: 80%; the middle value lies beyond the limit too.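

Compound 3 and compound 4 are both reported as limits in this assay, so no step between them can be read: the limit of > 10000 nM in this assay, at which 4 of the 4 values shown sit.

The compounds shown leave open which change, if any, would bring a readable value in this assay.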